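The source may hold more compounds than are shown below. What is called first, only, known or untested is meant among the compounds shown, and "the series" means these compounds.

In a functional assay on A549 cells (Homo sapiens) for antiproliferative activity, read by MTT assay, with a stated time of 48 h (on this read-out lower numbers stand for stronger inhibition and higher numbers for weaker inhibition), compound 1 `Oc1ccc2ccccc2c1C(Nc1nc2ccccc2s1)c1cn(-c2ccccc2)nc1-c1ccccc1` gives 36200 nM. Compound 2 `Oc1ccc2ccccc2c1C(Nc1nc2ccc(Cl)cc2s1)c1cn(-c2ccccc2)nc1-c1ccc(F)cc1`, which carries a 4-fluorophenyl group, gives 32200 nM. Compound 3 `Oc1ccc2ccccc2c1C(Nc1nc2ccc(Cl)cc2s1)c1cn(-c2ccccc2)nc1-c1cccc(Cl)c1`, which carries a 3-chlorophenyl group in its place, gives 33300 nM. Compound 3 therefore stands level with the other two compounds, since all three values lie within the scatter of one another.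

Compound 4 `Oc1ccc2ccccc2c1C(Nc1nc2ccc(Cl)cc2s1)c1cn(-c2ccccc2)nc1-c1ccccc1` follows from compound 3 by a single change: hydrogen in place of chloro on an aromatic carbon. Hydrogen takes the place of chloro on an aromatic carbon of a six-membered aromatic ring of carbon only, meta to a large group, so that 3-chlorophenyl becomes phenyl.

Among the measured compounds shown here, only one measured step touches this same group, a 1.0-fold higher number from compound 2 to compound 3 (0.01 log units; within the scatter), and it stays within the scatter. Compound 1 also carries the phenyl group, although it differs from compound 4 elsewhere. The value of compound 1, 36200 nM, lies close to the others. For the measured compounds named here, no measured step isolates the removal of this chloro, so the expectation remains an inference from these few compounds.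

The expected change, a 1.0-fold higher number from compound 3 to compound 4 (0.01 log units; within the scatter), is estimated to stay within the scatter, with no clear direction. In this assay the estimate for compound 4 is 34000 nM, with an expected range from 23000 nM to 50000 nM.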

Compound 4, half-maximal inhibitory concentration: 51100 nM
Compound 4: middle estimate off by 1.5-fold (0.18 log units), on the low side; the measured number lies above the stated range.
By their numbers in this assay, from the lowest: compounds 2, 3, 1 and 4 (each within the scatter of the next).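

In this assay, taking the chloro off the 3-chlorophenyl group, on an aromatic carbon meta to a large group, leaves the number within the scatter (a 1.5-fold higher number from compound 3 to compound 4 (0.19 log units; within the scatter)). Among the compounds shown here, the earlier step compared only one halogen-bearing phenyl group with another, whereas this result adds the plain phenyl group to that comparison, and the step against the 4-fluorophenyl group also stays within the scatter (a 1.6-fold higher number from compound 2 to compound 4 (0.20 log units; within the scatter)). The third new step, with chloro in place of hydrogen on an aromatic carbon of the other part of the molecule, likewise stays within the scatter (a 1.4-fold higher number from compound 1 to compound 4 (0.15 log units; within the scatter)), so on these compounds neither halogen separates from hydrogen at the places tested. Nothing given here bears on why these numbers lie so close together.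

The compounds shown carry only hydrogen, fluoro or chloro on these rings, so it remains open whether a larger or differently charged group, such as an amine, a carboxylic acid or a methoxy group, would move the number beyond the scatter. From the compounds shown here alone, whether the hydroxyl group of the shared core matters for the read-out also remains open.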